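A few compounds are considered here, and "the series" means these few. Any claim that something is new, unique, unknown or untested is made for them only; others in the source may bear on it.

Compound 2 `COc1cc(NC(C)CCCNC(=O)NNC(=O)NCCO)c2ncccc2c1` gives 27% in a physicochemical assay for inhibition, read by spectrophotometry, tested at 100 uM (on this read-out higher numbers stand for more inhibition at the one concentration tested (going by the name of the read-out) and lower numbers for less inhibition), the lowest of the two numbers recorded so far. For the measured compounds named here, its only measured neighbour, compound 1 `COc1cc(NC(C)CCCNC(=O)NNC(=O)Nc2ccc(Cl)c(C(F)(F)F)c2)c2ncccc2c1`, gives 63% in this assay, and the step of a number 36 percentage points lower from compound 1 to compound 2 (beyond the scatter) is large and beyond the scatter. Going by the values given here, that is the one step available for judging the next compound.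

Compound 3 `COc1cc(NC(C)CCCNC(=O)NNC(=O)NC(CO)(CO)CO)c2ncccc2c1` differs from compound 2 in a single place: 2-hydroxy-1,1-bis(hydroxymethyl)ethyl in place of 2-hydroxyethyl on an amide-type nitrogen.

The measured step bears on this only indirectly. Among the compounds with values here, the step of a number 36 percentage points lower from compound 1 to compound 2 (beyond the scatter) shows that exchanging the aryl group on this amide-type nitrogen for 2-hydroxyethyl lowered inhibition sharply, but no measured pair shows what happens when the hydroxy-bearing group on that nitrogen is enlarged. With nothing pointing in either direction, the move from compound 2 to compound 3 is expected to give only a small step, a number 5 percentage points lower from compound 2 to compound 3 (within the scatter), within the scatter, with a modest lean downward as the weaker side of the series is already reached. Compound 3 is therefore estimated at 22% in this assay, with a range from 8% to 40%.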

Compound 3, a percentage reported as inhibition, at one concentration (the size of the read-out at that concentration, not a potency): 49%
Beside the measured number, compound 3's estimate is 27 percentage points below it; measured number outside the range, above it.
By their numbers in this assay, from the lowest: compound 2; then compound 3; then compound 1.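

At this amide-type nitrogen, the size of the hydroxy-bearing group matters: in this assay the result is a number 22 percentage points higher from compound 2 to compound 3 (beyond the scatter) and shows that the position responds to a change between two groups without a ring, not only to the loss of the aryl group. The aryl group still keeps a lead, with a number 14 percentage points lower from compound 1 to compound 3 (beyond the scatter) as the step, so 2-hydroxy-1,1-bis(hydroxymethyl)ethyl regains only part of the ground lost with 2-hydroxyethyl while placing a group with no ring clearly above compound 2 in this read-out. Nothing among the available findings accounts for this rise.

The compounds shown cannot separate the effect of the added hydroxymethyl groups from that of the branched carbon carrying them, and a 1,1-dimethylethyl group, with the branching but no oxygen, or a 2,3-dihydroxypropyl group, with hydroxy groups on an unbranched chain, would pull these apart. They also leave open how an amine or a carboxylic acid on the end of a short chain at this nitrogen would compare with the hydroxy-bearing groups.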